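This account rests on a few compounds, and the source may have more. Where it says the series, first, only, none or still open, it means among the compounds named here.

Compound 1, `NNc1nonc1/C(=N/O)Nc1ccc(F)c(Br)c1`, is measured in an assay on HeLa cells for inhibition of Indoleamine 2,3-dioxygenase 1 (Homo sapiens), read by spectrophotometry, with a stated time of 24 h (a lower number here means that less compound is needed, a higher number that more compound is needed for the effect), and gives 556 nM. Among the compounds with a number, compound 1 stands highest of the two; the nearest is compound 2, `O=S1(=O)CC(Nc2nonc2/C(=N/O)Nc2ccc(F)c(Br)c2)C1`, which gives 59 nM, so that a 9.4-fold lower number from compound 1 to compound 2 (0.97 log units; beyond the scatter). Compound 3, `NNS(=O)(=O)CCNc1nonc1/C(=N/O)Nc1ccc(F)c(Br)c1`, reaches only a limit of this assay, > 800 nM, a value at which (the limit of > 800 nM in this assay, at which 1 of the 3 values shown sits).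

Compound 4, `CN(C)S(=O)(=O)CCCNc1nonc1/C(=N/O)Nc1ccc(F)c(Br)c1`, has not yet been measured. It differs from compound 1 in one place: 3-(dimethylsulfamoyl)propyl in place of amino on a nitrogen on an aromatic ring. Within the data shown here, two measured steps bear on this change. The change to a group with a ring gave a 9.4-fold lower number from compound 1 to compound 2 (0.97 log units; beyond the scatter), whereas the change to 2-(aminosulfamoyl)ethyl, a group with no ring, gave an at least 1.4-fold higher number from compound 1 to compound 3 (0.15 log units; that floor lies within the scatter), and between those two an at least 13-fold higher number from compound 2 to compound 3 (1.13 log units; beyond the scatter). Compound 4 carries a group with no ring, closer in kind to compound 3 than to compound 2, so the expectation is a step of a 1.6-fold higher number from compound 1 to compound 4 (0.21 log units; within the scatter), with a real chance that only a limit is reported. Compound 4 is therefore estimated at 900 nM, within a range from 300 nM to 3000 nM.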

Compound 4, half-maximal effective concentration: 20 nM
Compound 4: the middle estimate sits 45-fold (1.65 log units) above what was measured; the measured number lies below the stated range.
By their numbers in this assay, from the lowest: compound 4; then compound 2; then compound 1. At a limit, above all of these: compound 3.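

Placing 3-(dimethylsulfamoyl)propyl in place of amino on a nitrogen on an aromatic ring gave a 28-fold lower number from compound 1 to compound 4 (1.44 log units; beyond the scatter), and the step from the ring-bearing group gave a 3.0-fold lower number from compound 2 to compound 4 (0.47 log units; beyond the scatter), so a low number at this position does not depend on the four-membered ring of compound 2. Open chains ending in a sulfonyl group do not all behave alike here, as the change at this chain gave an at least 40-fold lower number from compound 3 to compound 4 (1.60 log units; beyond the scatter). That step starts from a limit, not a number, for compound 3: the limit of > 800 nM in this assay, at which 1 of the 4 values shown sits.

The compounds shown do not separate the length of the chain from the change at its end, since both differ together between compound 3 and compound 4. On these data alone, whether a longer chain, or a carboxylic acid or an amine at the chain end, would keep the number this low remains open.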